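Methyl extension on the alkyl chain of a corticotropin series

This account rests on a few compounds, and the source may have more. Where it says the series, first, only, none or still open, it means among the compounds named here.

Measured compounds in an assay for binding affinity to Corticotropin releasing factor receptor (Rattus norvegicus); on this read-out higher numbers stand for weaker inhibition and lower numbers for stronger inhibition: compound 1 `CCCC(C)n1c(CC)nc2c(-c3ccc(C(C)(C)O)cc3Cl)ccnc21` gives 24 nM; compound 2 `CCCC(C)n1c(CC)nc2c(-c3ccc(C(C)O)cc3Cl)ccnc21` gives 5.1 nM; compound 3 `CCc1nc2c(-c3ccc(Cl)cc3Cl)ccnc2n1C(C)CC` gives 1.3 nM.

Compound 1 and compound 2 differ by methyl in place of hydrogen on a saturated chain carbon bound to an aromatic carbon, an oxygen on a saturated carbon and a saturated chain carbon, and the step of a 4.7-fold higher number from compound 2 to compound 1 (0.67 log units; beyond the scatter) in this assay is modest but beyond the scatter. Compound 3 carries a different core; the difference between the cores of compound 2 and compound 3 is not broken down here.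

Compound 4 `CCc1nc2c(-c3ccc(Cl)cc3Cl)ccnc2n1C(CC)CC` is unmeasured and differs from compound 3 by methyl in place of hydrogen on a saturated chain carbon, two bonds along the chain from an aromatic nitrogen. This is the same kind of change as in the pair of compound 2 and compound 1, but the place differs: there the methyl enters on a saturated chain carbon bound to an aromatic carbon, an oxygen on a saturated carbon and a saturated chain carbon, while here it enters on a saturated chain carbon, two bonds along the chain from an aromatic nitrogen. The earlier step is therefore only a loose guide.

For compound 4 in this assay an inhibition constant of 1.8 nM is expected, with a range of 0.5 nM to 6 nM. The expected step of a 1.4-fold higher number from compound 3 to compound 4 (0.14 log units; within the scatter) is estimated to stay near the scatter, because compound 3 at 1.3 nM already sets the strongest number and the chain change sits away from the carbinol site that moved in the other pair.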

Compound 4, inhibition constant: 1 nM
Estimate against measurement, compound 4: 1.8-fold (0.26 log units) above; measured number inside the range.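

In this assay the added methyl gives a 1.3-fold lower number from compound 3 to compound 4 (0.11 log units; within the scatter), so on this core the change from sec-butyl to pentan-3-yl leaves the number within the scatter. The same kind of change does not carry the size of its step from one core to the other: the same change on two cores in this assay, a 4.7-fold higher number (0.67 log units; beyond the scatter) from compound 2 to compound 1 and a 1.3-fold lower number (0.11 log units; within the scatter) from compound 3 to compound 4, 6.1-fold (0.79 log units) apart, beyond the scatter of two such steps. The methyl also enters at a different place in each pair, and these data do not assign the gap to the core or to the place, while one pair per core gives no rule for the series.

Open, going by these compounds, is how a longer chain in place of pentan-3-yl reads in this assay. Also open, on these data alone, is how an amine in place of the hydroxyl of compound 2 reads there.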